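This account rests on a few compounds, and the source may have more. Where it says the series, first, only, none or still open, it means among the compounds named here.

The study centres on compound 1, `Cc1cc(C(=O)O)ccc1OCCCCOc1ccc(C(=O)CC(C)C)c(O)c1C`, which in an assay on HEK293 cells for positive allosteric modulation of metabotropic glutamate receptor 3 (Rattus norvegicus), read by thallium flux, with a stated time of 2.5 min (a lower number here means that less compound is needed, a higher number that more compound is needed for the effect), gives 1850 nM. Among the compounds considered, compound 1 holds the only single number in this assay; one further entry is a limit and one carries no result. Compound 2, `CCCC(=O)c1ccc(OCCCCOc2ccc(C(=O)O)cc2C)c(C)c1O`, reaches only the limit of this assay, recorded as > 10000 nM (the limit of > 10000 nM in this assay, at which 1 of the 3 values shown sits). Compound 3, `CCC(=O)c1ccc(OCCCCOc2ccc(C(=O)O)cc2C)c(C)c1O`, stands in this assay as "not determined" (no result reported). Going by the values given here, the single measured step, an at least 5.4-fold higher number from compound 1 to compound 2 (0.73 log units; beyond the scatter), concerns a methyl on the saturated chain of the ketone side and leaves the acid-bearing ring untouched.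

Compound 4, `Cc1cc(OCCCCOc2ccc(C(=O)CC(C)C)c(O)c2C)ccc1C(=O)O`, differs from compound 1 by 4-carboxy-3-methylphenyl in place of 4-carboxy-2-methylphenyl on an oxygen on a saturated carbon. Among the compounds with values here, no measured step touches the placement of the methyl on the acid-bearing ring, so the one step that exists does not bear on this change, and the comparison between compound 1 and compound 4 has no measured precedent in this set. With the shared core and the ketone side otherwise unchanged, the expectation for compound 4 rests on compound 1 alone. The expected step is a 1.6-fold higher number from compound 1 to compound 4 (0.21 log units; within the scatter), a movement that may well stay within the scatter. Compound 4 is therefore estimated at 3000 nM, with a range from 900 nM to 10000 nM.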

Compound 4, half-maximal effective concentration: 3910 nM
For compound 4 the middle estimate is 1.3-fold (0.12 log units) below the measured one; low and high end bracket the measured number.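

Placing the methyl as in 4-carboxy-3-methylphenyl rather than as in 4-carboxy-2-methylphenyl, on an oxygen on a saturated carbon, gives in this assay a 2.1-fold higher number from compound 1 to compound 4 (0.33 log units; beyond the scatter), the first measured step on the acid-bearing ring, whereas the earlier step lay on the ketone side. The number therefore responds to where the methyl sits on this ring, though only modestly, and compound 4 still gives a single number, with the ketone side and the rest of the shared core the same as in compound 1. Nothing at hand gives a cause for this step.

The compounds shown leave open whether the acid-bearing ring needs a methyl at all, as hydrogen in place of that methyl, or a chlorine or a methoxy group there, would show, and whether an amide or a tetrazole could stand in for the carboxylic acid. They also leave open how a longer or shorter chain in place of the saturated chain on the oxygen would read in this assay, and whether the two methyl placements would rank the same way with another ketone side.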